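Morpholine amide of a naphthyl pyridine, inhibition measured

This account rests on a few compounds, and the source may have more. Where it says the series, first, only, none or still open, it means among the compounds named here.

Compound 1 `CNC(=O)/C=C/c1ccncc1-c1ccc2ccccc2c1` is an acrylamide bearing a methylamino group on its carbonyl carbon. In an assay on a protein complex for inhibition of CDK8/Cyclin C (Homo sapiens), with a stated time of 1 h, tested at 10 uM (on this read-out lower numbers stand for less inhibition and higher numbers for more inhibition at the one concentration tested (going by the name of the read-out)), compound 1 gives 101%, and this number lies within the scatter of both companions: compound 2 `NNC(=O)CCc1ccncc1-c1ccc2ccccc2c1` gives 102% in this assay, and compound 3 `O=C(/C=C/c1ccncc1-c1ccc2cc[nH]c2c1)N1CCOCC1` gives 102%. The step of a number 1 percentage points higher from compound 1 to compound 2 (within the scatter) shows that reworking the amide end of the chain leaves this assay unchanged. Compound 4 `O=C(/C=C/c1ccncc1-c1ccc2ccccc2c1)N1CCOCC1` differs from compound 1 by morpholin-4-yl in place of methylamino on a carbonyl carbon. Compound 3 carries the same (morpholin-4-yl)carbonyl group on a different core and sits at the same plateau. A step of a number 1 percentage points lower from compound 1 to compound 4 (within the scatter) is therefore expected, none beyond the scatter. For compound 4 the expected value is 100%, between 90% and 105%.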

Compound 4, a percentage reported as inhibition, at one concentration (the size of the read-out at that concentration, not a potency): 99%
Estimate against measurement, compound 4: 1 percentage points above, and the stated range covers the measured number.
By their numbers in this assay, from the lowest: compounds 4, 1, 2 and 3 (each within the scatter of the next).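

On a carbonyl carbon whose other neighbour is the double-bonded chain carbon, morpholin-4-yl in place of methylamino gives, in this assay, a number 2 percentage points lower from compound 1 to compound 4 (within the scatter). On the shared core, this position therefore accepts a six-membered non-aromatic ring and the loss of the hydrogen-bond donor with no change beyond the scatter, which the earlier compounds had not shown. No evidence bears on why the number holds.

All four compounds lie within the scatter of one another at this single concentration, so the read-out does not separate them. As far as these compounds go, whether a carboxylic acid or a piperazine at this carbonyl carbon would leave this plateau remains open.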